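Benzyl Amide Halogenation Probed for Mouse Liver Clearance

The source may report more compounds than this note shows. Statements on the series, on what has been measured and on what is new or still open speak of the compounds shown alone.

Measured so far:
compound 1, `CNc1[nH]c(=O)n(O)c(=O)c1C(=O)NCc1ccccc1`: 500 uL/min
compound 2, `CCNc1[nH]c(=O)n(O)c(=O)c1C(=O)NCc1ccccc1`: 732 uL/min

The two compounds share one core and differ only at the chain on the ring nitrogen. In an ADME assay on microsomes from liver (Mus musculus) for metabolic stability (on this read-out lower numbers stand for slow clearance and higher numbers for fast clearance), compound 1 gives 500 uL/min and compound 2 gives 732 uL/min. Within the data shown here, the only step so far, a 1.5-fold higher number from compound 1 to compound 2 (0.17 log units; within the scatter), keeps these two within the scatter of each other, so compound 2 stands level with compound 1 on the numbers available.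

Compound 3, `CCNc1[nH]c(=O)n(O)c(=O)c1C(=O)NCc1cccc(Cl)c1F`, is not yet measured. It differs from compound 2 by 3-chloro-2-fluorophenyl in place of phenyl on a saturated chain carbon bound to an amide-type nitrogen. Among the measured compounds shown here, no measured step touches this part of the molecule: the one step known concerns the chain on the ring nitrogen, not the benzyl group, and it was small. There is therefore no basis in the data for expecting a shift beyond the scatter in this assay in either direction.

Compound 3 is accordingly expected to give about 650 uL/min in this assay, within a range from 300 uL/min to 1400 uL/min. The expected step of a 1.1-fold lower number from compound 2 to compound 3 (0.05 log units; within the scatter) is estimated to stay within the scatter.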

Compound 3, intrinsic clearance in a liver preparation (reported as CLH), per the amount of preparation that the assay uses: 1070 uL/min
Compound 3: middle estimate off by 1.6-fold (0.22 log units), on the low side; measured number inside the range.
By their numbers in this assay, from the lowest: compounds 1, 2 and 3 (each within the scatter of the next, the first and the last beyond it).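

Among these compounds, the change at the benzyl end of the molecule is the first one tested at this place: in this assay, putting 3-chloro-2-fluorophenyl in place of phenyl on a saturated chain carbon bound to an amide-type nitrogen gives a 1.5-fold higher number from compound 2 to compound 3 (0.16 log units; within the scatter) and so does not carry the read-out beyond the scatter. Within these two compounds, then, a chlorine and a fluorine can both enter the ring, taking the group from 6 to 8 heavy atoms, without a step that can be told apart from repeated measurement. Nothing available gives a reason for the size of this step or says what in the molecule sets the clearance.

Chlorine and fluorine enter together here, so what each halogen would do alone on the phenyl ring remains open, as does the outcome of replacing the phenyl with a pyridine ring or adding a methoxy group to it. From the compounds shown here alone, it also remains open whether a longer chain on the ring nitrogen, such as propyl, would give a step beyond the scatter when paired with the 3-chloro-2-fluorophenyl group.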